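This account rests on a few compounds, and the source may have more. Where it says the series, first, only, none or still open, it means among the compounds named here.

Working notes on the series.

Compound 1 `Cc1ccc2c(O)cc(-c3cccc(Cl)c3)nc2n1` is the reference point here. In a functional assay on CAKI-1 cells (Homo sapiens) for antiproliferative activity (a lower number here means a stronger inhibitor of growth, a higher number a weaker inhibitor of growth), compound 1 gives 41.7 nM, the lowest number among the three measured compounds. Compound 3 `Cc1cnc2[nH]c(-c3cccc(Cl)c3)cc(=O)c2c1` gives 42.7 nM in this assay, which lies within the scatter of the value for compound 1; the two results are not separable. Compound 2 `Cc1cc(C)c2c(O)cc(-c3ccc4ccccc4c3)nc2n1` gives 51300 nM in this assay, a result far beyond the scatter from compound 1 and the widest gap in the set.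

Compound 4 `Cc1cccc(-c2cc(O)c3ccc(C)nc3n2)c1` has not yet been measured. It differs from compound 1 in one place: methyl in place of chloro on an aromatic carbon. Among the measured compounds shown here, no measured pair in the set isolates this exchange, so no directly comparable step is known. The expectation is that the step from compound 1 to compound 4 stays small, with no direction beyond the scatter: a 1.4-fold higher number from compound 1 to compound 4 (0.16 log units; within the scatter) is the estimated step. Compound 4 is therefore expected to give about 60 nM in this assay, within a range of 20 nM to 200 nM.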

Compound 4, concentration for 50% growth inhibition: 427 nM
Compound 4: the middle estimate sits 7.1-fold (0.85 log units) below what was measured; the whole stated range lies below it.
By their numbers in this assay, from the lowest: compounds 1 and 3 (each within the scatter of the next); then compound 4; then compound 2.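

At this place, on an aromatic carbon meta to a large group, methyl in place of chloro gives a 10-fold higher number from compound 1 to compound 4 (1.01 log units; beyond the scatter) in this assay and so shows that the position is sensitive to what it carries. Among the compounds shown here, this is the first exchange isolated in one place, and the two groups, each of a single heavy atom with no hydrogen-bond donors or acceptors and no net charge, are not interchangeable here. No measurement at hand bears on what lies behind this step.

On these data alone, whether other groups at this place, such as fluoro, methoxy or an amine, stay close to chloro or fall nearer to methyl remains open. Also open, as far as these compounds go, is whether the same exchange on the core of compound 3 would give a step of similar size.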